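Benzothiazole cap in place of bromophenyl

The source may hold more compounds than are shown below. What is called first, only, known or untested is meant among the compounds shown, and "the series" means these compounds.

Three analogues with a shared chain capped by a trifluoromethyl diol have been measured in an assay on isolated protein for inhibition of protein deacetylase HDAC6 (Homo sapiens), read by chemiluminescence, with a stated time of 3 h; on this read-out lower numbers stand for stronger inhibition and higher numbers for weaker inhibition. Compound 1 `COc1ccc2sc(NC(=O)CCCCCCNC(=O)C(O)(O)C(F)(F)F)nc2c1` gives 100000 nM. Compound 2 `O=C(CCCCCCNC(=O)C(O)(O)C(F)(F)F)Nc1ccc(Br)cc1` gives 100000 nM, level with compound 1 at the digits shown, and the two together stand as the highest pair among the three numbers. Compound 3 `O=C(CCCCCCNC(=O)C(O)(O)C(F)(F)F)Nc1ccc(-c2ccccc2)cc1` gives 38000 nM; the step of a 2.6-fold lower number from compound 2 to compound 3 (0.42 log units; beyond the scatter) is modest yet beyond the scatter. The untested compound 4 `O=C(CCCCCCNC(=O)C(O)(O)C(F)(F)F)Nc1nc2ccccc2s1` arises from compound 2 by 1,3-benzothiazol-2-yl in place of 4-bromophenyl on an amide-type nitrogen. For the measured compounds named here, no measured step covers that exact exchange. Going by the values given here, the only step at the same position, a 2.6-fold lower number from compound 2 to compound 3 (0.42 log units; beyond the scatter), concerns a different group. More directly relevant is compound 1, with 100000 nM, which differs from compound 4 by a methoxy group alone and sits level with compound 2. Compound 4 is therefore expected to show no change beyond the scatter, no change at the digits printed from compound 2 to compound 4 (within the scatter). Compound 4 is estimated at 100000 nM, with a range from 40000 nM to 200000 nM.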

Compound 4, half-maximal inhibitory concentration: 82000 nM
The estimate for compound 4 lay 1.2-fold (0.09 log units) above the measured number; the range from low to high includes it.
By their numbers in this assay, from the lowest: compound 3; then compounds 4, 1 and 2 (each within the scatter of the next).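

In this assay the step from the single ring of 4-bromophenyl to the two rings of 1,3-benzothiazol-2-yl on the amide-type nitrogen is a 1.2-fold lower number from compound 2 to compound 4 (0.09 log units; within the scatter) and so cannot be told from no change, which shows that this larger cap, unlike the phenyl of compound 3, gives no measurable gain here. Compound 4 also shows that the methoxy group of compound 1 makes no difference that can be read, with a 1.2-fold lower number from compound 1 to compound 4 (0.09 log units; within the scatter) as the step for hydrogen in its place. Nothing at hand accounts for either result.

The compounds shown leave open whether a phenyl, an amine or a carboxylic acid on the aromatic carbon that carries methoxy in compound 1 would move the number beyond the scatter. They also leave open whether a longer chain would change the number with either cap.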